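The source may hold more compounds than are shown below. What is called first, only, known or untested is meant among the compounds shown, and "the series" means these compounds.

Of the compounds shown here, three built on one shared core have been measured in an assay on CHO-K1 cells for displacement of a labelled ligand from prostaglandin E2 receptor EP1 subtype (Homo sapiens); a higher number here means a weaker inhibitor, a lower number a stronger inhibitor. Compound 1 `Cc1cc(C(=O)Nc2ccccc2)nn1Cc1cc(Cl)ccc1OCc1ccccc1` gives 39.8 nM, compound 2 `Cc1cc(C(=O)Nc2c(F)cccc2F)nn1Cc1cc(Cl)ccc1OCc1ccccc1` gives 10 nM, and compound 3 `Cc1cc(NC(=O)C2CCCO2)nn1Cc1cc(Cl)ccc1OCc1ccccc1` gives 39.8 nM. Compound 3 thus stands level with compound 1, the two together the highest numbers of the three, while a 4.0-fold higher number from compound 2 to compound 3 (0.60 log units; beyond the scatter). Compound 4 `Cc1cc(NC(=O)OCc2ccccn2)nn1Cc1cc(Cl)ccc1OCc1ccccc1` differs from compound 3 in one place: (pyridin-2-yl)methoxy in place of oxolan-2-yl on a carbonyl carbon. Going by the values given here, no measured step alters this particular group, but the nearby steps show what this region tolerates: no change at the digits printed from compound 1 to compound 3 (within the scatter) and a 4.0-fold lower number from compound 1 to compound 2 (0.60 log units; beyond the scatter). A step of at most modest size, with no sure direction, is therefore expected, and the estimated step reads a 1.6-fold lower number from compound 3 to compound 4 (0.20 log units; within the scatter). Compound 4 is expected to give about 25 nM, within 8 nM to 80 nM.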

Compound 4, half-maximal inhibitory concentration: 79.4 nM
Compound 4: the middle estimate sits 3.2-fold (0.50 log units) below what was measured, and the stated range covers the measured number.
By their numbers in this assay, from the lowest: compound 2; then compounds 1, 3 and 4 (each within the scatter of the next).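

Putting (pyridin-2-yl)methoxy in place of oxolan-2-yl on a carbonyl carbon gives a 2.0-fold higher number from compound 3 to compound 4 (0.30 log units; within the scatter) and shows that this position accepts a six-membered aromatic ring as well as a five-membered non-aromatic one. Likewise, a 2.0-fold higher number from compound 1 to compound 4 (0.30 log units; within the scatter) stays inside the scatter, whereas a 7.9-fold higher number from compound 2 to compound 4 (0.90 log units; beyond the scatter) is beyond it, which leaves compound 2 apart from the other three. Going by these compounds, whether an amine or a longer alkyl chain on this carbonyl carbon would fit the same level remains open. Nothing available explains these numbers.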